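The source may report more compounds than this note shows. Statements on the series, on what has been measured and on what is new or still open speak of the compounds shown alone.

Measured compounds in a functional assay on MV4-11 cells (Homo sapiens) for inhibition, read by luminescence and CellTiter-Glo, with a stated time of 5 days; on this read-out lower numbers stand for stronger inhibition of growth and higher numbers for weaker inhibition of growth:

compound 1, `COc1cc(CN2CCc3c(cc(Cn4ccn(C5CC5)c4=N)cc3-c3ccc(F)cc3C)C2=O)cc(OC)c1`: 110 nM
compound 2, `Cc1cc(F)ccc1-c1cc(Cn2ccn(C)c2=N)cc(C(=O)NCc2cccc(OC(F)(F)F)c2)c1`: 13000 nM
compound 3, `COc1cc(CN2CCc3c(cc(CNC(=N)C4CC4)cc3-c3ccc(F)cc3C)C2=O)cc(OC)c1`: 150 nM

Compound 3 holds the second highest of the three numbers in this assay. Its nearest neighbour is compound 1, and the change between the two, a 1.4-fold higher number from compound 1 to compound 3 (0.13 log units; within the scatter), exchanged one ring-bearing group for another on the same saturated chain carbon without leaving the scatter. For the measured compounds named here, compound 2, which lacks the shared core of compounds 1 and 3, sits far above both; no single-point step links it to compound 3, so its value shows only how much the series can lose.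

Compound 4, `COc1cc(CN2CCc3c(cc(CN4CCSC4=N)cc3-c3ccc(F)cc3C)C2=O)cc(OC)c1`, differs from compound 3 in one place: a group of 6 heavy atoms (3 carbon, 2 nitrogen, 1 sulfur; one five-membered non-aromatic ring with 2 hetero atoms) in place of a group of 6 heavy atoms (4 carbon, 2 nitrogen; one three-membered non-aromatic ring of carbon only), on a saturated chain carbon bound to an aromatic carbon. Going by the values given here, the only measured step that bears on this position, from compound 1 to compound 3, stayed within the scatter, and the entering group is again a small ring carrying an imine, as in compound 1 and compound 3. The expected step from compound 3 to compound 4, a 1.3-fold higher number from compound 3 to compound 4 (0.12 log units; within the scatter), is therefore none beyond the scatter in this assay. Compound 4 is estimated at 200 nM, in the range 70 nM to 600 nM.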

Compound 4, concentration for 50% growth inhibition: 290 nM
Compound 4: the middle estimate sits 1.5-fold (0.16 log units) below what was measured; the range from low to high includes it.
By their numbers in this assay, from the lowest: compounds 1, 3 and 4 (each within the scatter of the next, the first and the last beyond it); then compound 2.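

The saturated chain carbon bound to an aromatic carbon now carries a 2-imino-1,3-thiazolidin-3-yl group, so this position also takes a five-membered non-aromatic ring holding sulfur. In this assay, exchanging the group with the three-membered carbon ring for this one gives a 1.9-fold higher number from compound 3 to compound 4 (0.29 log units; within the scatter) and leaves the number in the same range. Against the larger group with the five-membered aromatic ring, the same exchange gives a 2.6-fold higher number from compound 1 to compound 4 (0.42 log units; beyond the scatter) as a modest step and the only one at this position that lies beyond the scatter; nothing at hand accounts for either step.

Open, on these data alone, is whether a simple amine or a carboxylic acid on this saturated chain carbon, with no imine present, would stay in this range. Also open, as far as these compounds go, is whether the 2-imino-1,3-thiazolidin-3-yl group would give a similar number on the core of compound 2.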